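A few compounds are considered here, and "the series" means these few. Any claim that something is new, unique, unknown or untested is made for them only; others in the source may bear on it.

Of the compounds shown here, three share one core and have been tested in a functional assay on A549 cells (Homo sapiens) for inhibition, read by MTT assay, with a stated time of 48 h; on this read-out lower numbers stand for stronger inhibition and higher numbers for weaker inhibition. Compound 1 `COc1ccccc1-c1csc(N/N=C/c2cc(OC)c(OC)c(Br)c2Br)n1` gives 85100 nM. Compound 2 `COc1cc(/C=N/Nc2nc(-c3cccc(Br)c3)cs2)c(Br)c(Br)c1OC` gives 37000 nM, the lowest of the three numbers; the change a 2.3-fold lower number from compound 1 to compound 2 (0.36 log units; beyond the scatter) lies beyond the scatter. Compound 3 `COc1cc(/C=N/Nc2nc(-c3cccc(Br)c3)cs2)cc(Br)c1OC` gives 56000 nM, and the change a 1.5-fold higher number from compound 2 to compound 3 (0.18 log units; within the scatter) stays within the scatter. Compound 4 `COc1cc(/C=N/Nc2nc(-c3ccc(Br)cc3)cs2)c(Br)c(Br)c1OC` has not yet been measured and differs from compound 2 in one place: 4-bromophenyl in place of 3-bromophenyl on an aromatic carbon. Within the data shown here, no measured step exchanges 3-bromophenyl for 4-bromophenyl; the step from compound 1 to compound 2 swaps the whole group, and the step from compound 2 to compound 3 removes a bromine. The step of a 1.1-fold higher number from compound 2 to compound 4 (0.03 log units; within the scatter) is therefore expected to stay within the scatter. Compound 4 is estimated at 40000 nM, between 18000 nM and 90000 nM.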

Compound 4, half-maximal inhibitory concentration: 46100 nM
Estimate against measurement, compound 4: 1.2-fold (0.06 log units) below; measured number inside the range.
By their numbers in this assay, from the lowest: compounds 2, 4, 3 and 1 (each within the scatter of the next, the first and the last beyond it).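

Changing 3-bromophenyl to 4-bromophenyl on the shared core stays within the scatter (a 1.2-fold higher number from compound 2 to compound 4 (0.10 log units; within the scatter)), so in this assay these two bromophenyl groups cannot be told apart at this position. Exchanging 2-methoxyphenyl for 4-bromophenyl also stays within the scatter (a 1.8-fold lower number from compound 1 to compound 4 (0.27 log units; within the scatter)), while the exchange for 3-bromophenyl lies just beyond it (a 2.3-fold lower number from compound 1 to compound 2 (0.36 log units; beyond the scatter)), a contrast too slight to read as real. Nothing available here explains these results. As far as these compounds go, whether an amine or a carboxylic acid on this phenyl ring would shift the number remains open.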